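A few compounds are considered here, and "the series" means these few. Any claim that something is new, unique, unknown or untested is made for them only; others in the source may bear on it.

Measured compounds, with their numbers in an assay on LM cells for displacement of a labelled ligand from Neuropeptide Y receptor type 5 (Homo sapiens); a lower number here means a stronger inhibitor, a higher number a weaker inhibitor:
compound 1 `O=[N+]([O-])c1cccc(C2=NC(c3ccc(F)cc3)(c3ccc(F)cc3)CN2)c1`: 4.3 nM
compound 2 `Cc1cccc(C2=NC(c3ccc(F)cc3)(c3ccc(F)cc3)CN2)c1`: 30 nM
compound 3 `OCc1cccc(C2=NC(c3ccc(F)cc3)(c3ccc(F)cc3)CN2)c1`: 59 nM

Compound 3 gives the highest of the three numbers in this assay. Its nearest neighbour is compound 2, the difference being a 2.0-fold higher number from compound 2 to compound 3 (0.29 log units; within the scatter), which is within the scatter; the gap to compound 1, a 14-fold higher number from compound 1 to compound 3 (1.14 log units; beyond the scatter), lies beyond it, as does a 7.0-fold higher number from compound 1 to compound 2 (0.84 log units; beyond the scatter).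

Compound 4 `Fc1ccc(C2(c3ccc(F)cc3)CNC(c3ccsc3)=N2)cc1` is not yet measured. It differs from compound 3 in that (thiophen-3-yl in place of 3-(hydroxymethyl)phenyl on a carbon with a double bond to nitrogen). Within the data shown here, none of the measured steps exchanges the aromatic ring on that carbon; all three only vary the group carried on the phenyl ring. Of those, a 14-fold higher number from compound 1 to compound 3 (1.14 log units; beyond the scatter) and a 7.0-fold higher number from compound 1 to compound 2 (0.84 log units; beyond the scatter) were clear shifts, while a 2.0-fold higher number from compound 2 to compound 3 (0.29 log units; within the scatter) was not. Among the measured compounds shown here, an aromatic ring bearing no group at all, and a five-membered one, has no precedent, so the expectation rests loosely on compound 2 and compound 3 rather than on a matching step. For compound 4 in this assay the estimate is 90 nM, range 25 nM to 300 nM. The expected step is a 1.5-fold higher number from compound 3 to compound 4 (0.18 log units; within the scatter), that is, either within the scatter or modestly towards a higher number.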

Compound 4, half-maximal inhibitory concentration: 93 nM
The estimate for compound 4 lay 1.0-fold (0.01 log units) below the measured number, and the stated range covers the measured number.
By their numbers in this assay, from the lowest: compound 1; then compounds 2, 3 and 4 (each within the scatter of the next, the first and the last beyond it).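

In this assay the aromatic ring on the carbon with a double bond to nitrogen can itself be exchanged, not only the group it carries: a 1.6-fold higher number from compound 3 to compound 4 (0.20 log units; within the scatter) leaves thiophen-3-yl and 3-(hydroxymethyl)phenyl indistinguishable. Against the other two phenyl compounds the same exchange does cost potency, with a 3.1-fold higher number from compound 2 to compound 4 (0.49 log units; beyond the scatter) and a 22-fold higher number from compound 1 to compound 4 (1.34 log units; beyond the scatter) as the largest step in the set, so thiophen-3-yl does not match 3-methylphenyl and stays far from 3-nitrophenyl. Nothing available accounts for these steps.

An unsubstituted phenyl ring at this carbon would be needed to separate the effect of changing the ring from that of losing the group it carries. Also open, on these data alone, are whether a nitro group on thiophen-3-yl would lower the number as it does on phenyl, and how a pyridyl or furanyl ring would read here.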